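This account rests on a few compounds, and the source may have more. Where it says the series, first, only, none or still open, it means among the compounds named here.

In a functional assay on HeLa cells for agonist activity at 5-hydroxytryptamine receptor 6 (Homo sapiens), read by cAMP accumulation and immunoassay (on this read-out higher numbers stand for an effect only at larger amounts of compound and lower numbers for an effect already at smaller amounts), the measured compounds stand as follows: compound 1 `O=S(=O)(c1ccc(F)cc1)c1cn(C2CCNC2)c2ncccc12`, 1650 nM; compound 2 `CN1CCC(n2cc(S(=O)(=O)c3ccccc3)c3cccnc32)C1`, 2040 nM; compound 3 `O=S(=O)(c1ccccc1)c1cn(C2CCCNC2)c2ncccc12`, 47 nM.

Within the data shown here, compound 3 gives the lowest number of the three, separated from compound 1 and compound 2 by gaps beyond the scatter; the only single-place step, a 43-fold lower number from compound 2 to compound 3 (1.64 log units; beyond the scatter), is large. Compound 4 `O=S(=O)(c1cccc(Cl)c1)c1cn(C2CCCNC2)c2ncccc12` differs from compound 3 by chloro in place of hydrogen on an aromatic carbon. Among the measured compounds shown here, no measured step bears on a change of this kind: compound 1 also carries a halogen on the phenyl ring, but it differs from compound 3 in the amine as well, so its higher value is no guide. The step is therefore expected to be small, a 1.2-fold lower number from compound 3 to compound 4 (0.07 log units; within the scatter). For compound 4 the expected value in this assay is 40 nM, with a range from 12 nM to 130 nM.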

Compound 4, half-maximal effective concentration: 30 nM
The estimate for compound 4 lay 1.3-fold (0.12 log units) above the measured number; low and high end bracket the measured number.
By their numbers in this assay, from the lowest: compounds 4 and 3 (each within the scatter of the next); then compounds 1 and 2 (each within the scatter of the next).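

In this assay, chloro in place of hydrogen on the aromatic carbon meta to a large group gives a 1.6-fold lower number from compound 3 to compound 4 (0.19 log units; within the scatter). Among these compounds, this is the only single-place step on the phenyl ring, and it shows that, with piperidin-3-yl held fixed, this position accepts chloro without a change beyond the scatter. Nothing measured here offers an explanation for this result. Going by these compounds, whether a methoxy group or bromo at this place would also stay within the scatter of compound 3 remains open. So does the outcome of chloro at another carbon of this ring.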